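Swapping a Sulfonamide for a Tolyl Group

The source may hold more compounds than are shown below. What is called first, only, known or untested is meant among the compounds shown, and "the series" means these compounds.

Going by the values given here, compound 2 `O=C1O[C@H]([C@@H](O)Cn2cc(CNS(=O)(=O)c3ccc(F)cc3)nn2)C(OCc2ccccc2)=C1OCc1ccccc1` is the one member of this small set with a number rather than a limit: in an ADME assay on HFF cells (Homo sapiens) for cytotoxicity, read by MTT assay, with a stated time of 72 h (on this read-out lower numbers stand for stronger inhibition and higher numbers for weaker inhibition), compound 2 gives 30 nM. Compound 1 `COc1ccc(-c2cn(C/C=C3\OC(=O)C(OCc4ccccc4)=C3OCc3ccccc3)nn2)cc1` reaches only a limit, and in this assay compound 1 gives > 100000 nM; this is the limit of the assay, not a measured number, as stated in the limit of > 100000 nM in this assay, at which 1 of the 2 values shown sits. Compound 3 `Cc1ccc(-c2cn(C[C@H](O)[C@H]3OC(=O)C(OCc4ccccc4)=C3OCc3ccccc3)nn2)cc1` has not yet been measured in this assay. It differs from compound 2 in one place: 4-methylphenyl in place of (((4-fluorophenyl)sulfonyl)amino)methyl on an aromatic carbon. Among the compounds with values here, no step between measured compounds that differ in one place is available, so the size of the change can only be guessed. The author expects the step from compound 2 to compound 3 to weaken the cytotoxic effect well beyond the scatter, at a 100-fold higher number from compound 2 to compound 3 (2.00 log units; beyond the scatter). Compound 3 is therefore estimated at 3000 nM, within a range from 200 nM to 50000 nM.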

Compound 3, half-maximal inhibitory concentration: > 100000 nM
Compound 3 was reported as a limit (the forecaster's own chance of this, stated with the estimate: 25%); middle value at least 33-fold (1.52 log units) from the limit.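

Going by these compounds alone, this step is the first measured change at this position, an aromatic carbon of the five-membered ring with 3 nitrogen, and in this assay putting 4-methylphenyl in place of (((4-fluorophenyl)sulfonyl)amino)methyl gives an at least 3300-fold higher number from compound 2 to compound 3 (3.52 log units; beyond the scatter). Compound 3 stands at a limit of the assay and not at a number, so the step gives only a minimum size: the limit of > 100000 nM in this assay, at which 2 of the 3 values shown sit. In this pair, the core shared by compound 2 and compound 3 does not by itself carry the cytotoxic effect seen for compound 2, and the group at this position decides the outcome.

The compounds shown do not tell which part of the departing group counts: the sulfonyl, its amino nitrogen, the 4-fluorophenyl ring or the methyl link. A plain aminomethyl group or a carboxylic acid at this position could begin to separate these parts.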